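From Sulfamoyl to Hydroxymethyl on a Shared Core

A few compounds are considered here, and "the series" means these few. Any claim that something is new, unique, unknown or untested is made for them only; others in the source may bear on it.

Compound 1 `CCc1ccc(-c2ccc(NC3=CC(=O)c4ncncc4C3=O)cc2)cc1` gives 1200 nM in a functional assay on PANC-1 cells (Homo sapiens) for cytotoxicity, read by MTT assay, with a stated time of 72 h; a higher number here means a weaker inhibitor, a lower number a stronger inhibitor.
Compound 2 `NS(=O)(=O)c1ccc(NC2=CC(=O)c3ncncc3C2=O)cc1` is reported in this assay only as a limit, > 10000 nM.

Among the compounds with values here, the single measured step, an at least 8.3-fold higher number from compound 1 to compound 2 (0.92 log units; beyond the scatter), runs from a number to a limit, so its true size is open-ended. Compound 2 therefore stands at the limit (the limit of > 10000 nM in this assay, at which 1 of the 2 values shown sits), and no number for it is known.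

Compound 3 `O=C1C(Nc2ccc(CO)cc2)=CC(=O)c2ncncc21` has not yet been measured in this assay. It differs from compound 2 by hydroxymethyl in place of sulfamoyl on an aromatic carbon. Within the data shown here, the step from compound 1 to compound 2 is the only measured change at this position, and it is at least modest; it shows that a small polar group here gives a weaker inhibitor than 4-ethylphenyl, but it gives no number to anchor where a hydroxymethyl would fall. Hydroxymethyl is likewise small and polar, so compound 3 is expected to land near the weak end of the range seen, with a real chance that this assay again reports only a limit. The estimate for compound 3 is 8000 nM, within 3000 nM to 20000 nM, a change of an at least 1.2-fold lower number from compound 2 to compound 3 (0.09 log units; that floor lies within the scatter).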

Compound 3, half-maximal inhibitory concentration: 1000 nM
Estimate against measurement, compound 3: 8.0-fold (0.90 log units) above, and the stated range ends above it.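

In this assay the change to hydroxymethyl (an at least 10-fold lower number from compound 2 to compound 3 (1.00 log units; beyond the scatter)) shows that the loss seen with sulfamoyl does not carry over to every group placed here on the shared core. The 4-ethylphenyl group of compound 1 also proves not to be needed to keep this level of cytotoxicity: the step to hydroxymethyl (a 1.2-fold lower number from compound 1 to compound 3 (0.08 log units; within the scatter)) leaves compound 1 and compound 3 with no difference beyond the usual scatter, even though one group replaces the other outright. The true size of the step from sulfamoyl to hydroxymethyl stays open-ended because compound 2 is held only at a limit: the limit of > 10000 nM in this assay, at which 1 of the 3 values shown sits.

The compounds shown do not reveal what separates hydroxymethyl from sulfamoyl, since the two groups differ in several counted features at once, and it remains open whether an amine, a carboxylic acid or a longer chain such as hydroxyethyl would follow compound 3 or compound 2. They also leave unsettled whether the match between compound 1 and compound 3 would hold for a plain hydroxyl or a methoxy group at the same place.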